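The source may hold more compounds than are shown below. What is called first, only, known or untested is meant among the compounds shown, and "the series" means these compounds.

Measured so far in a functional assay on 1321-N1 cells for agonist activity at Free fatty acid receptor 1 (Homo sapiens), read by calcium flux; a higher number here means that more compound is needed for the effect, a lower number that less compound is needed:
compound 1 `O=C(O)CCc1ccc(OCc2ccc(Oc3ccccc3)cc2)cc1`, giving 204 nM
compound 2 `O=C(O)CCc1ccc(NCc2ccc(Oc3ccccc3)cc2)cc1`, giving 182 nM
compound 3 `O=C(O)CCc1ccc(OCc2ccc(-c3ccccc3)cc2)cc1`, giving 912 nM

Compound 1 and compound 2 differ in their cores, and the difference between the two cores is not broken down here; in this assay their values lie within the scatter of one another. Among the compounds with values here, the single counted change in the set is phenyl in place of phenoxy on an aromatic carbon, and that change gave a 4.5-fold higher number from compound 1 to compound 3 (0.65 log units; beyond the scatter).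

Compound 4 `O=C(O)CCc1ccc(NCc2ccc(-c3ccccc3)cc2)cc1` is not yet measured. Within the data shown here, it differs from compound 2 by phenyl in place of phenoxy on an aromatic carbon, the same change at the same place as the one from compound 1 to compound 3. The step to compound 4 is expected to be a 4.5-fold higher number from compound 2 to compound 4 (0.65 log units; beyond the scatter), resting on the earlier step of a 4.5-fold higher number from compound 1 to compound 3 (0.65 log units; beyond the scatter). Compound 4 is therefore estimated at 820 nM, with a likely range from 350 nM to 2000 nM.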

Compound 4, half-maximal effective concentration: 417 nM
Compound 4: the middle estimate sits 2.0-fold (0.29 log units) above what was measured, within the range that was stated.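

In this assay, phenyl in place of phenoxy on an aromatic carbon gave a 2.3-fold higher number from compound 2 to compound 4 (0.36 log units; beyond the scatter), so the number rises on this core too. The change carries across these two cores in direction, and the two steps cannot be told apart in size: the same change on two cores in this assay, a 4.5-fold higher number (0.65 log units; beyond the scatter) from compound 1 to compound 3 and a 2.3-fold higher number (0.36 log units; beyond the scatter) from compound 2 to compound 4, 2.0-fold (0.29 log units) apart, within the scatter of two such steps. Within the data shown here, this rests on only two pairs, so it does not establish transfer to any other core, nor does it explain why the number rises.

Still open, as far as these compounds go, is whether the same step holds when a benzyl or methoxy group replaces phenoxy. Also open, from the compounds shown here alone, is whether it survives on cores with an amide linker or a longer chain carrying the carboxylic acid.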